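The compounds below may be only part of what the source reports. "The series", "measured", "known", "first", "only" and "open" are said of these compounds alone.

Compound 1 `O=C(NNS(=O)(=O)c1ccccc1F)c1cc(F)cc(-n2cccn2)c1`: 1.6 h
Compound 2 `Cc1cc(-n2cccn2)cc(C(=O)NNS(=O)(=O)c2ccccc2)c1F`: 1.25 h
Compound 3 `C=CCOc1cc(F)cc(C(=O)NNS(=O)(=O)c2ccccc2F)c1`: 0.217 h

These numbers come from an ADME assay on microsomes from liver (Homo sapiens) for metabolic stability, read by HPLC, using NADPH, with a stated time of 60 min, tested at 1 uM, in the presence of a further agent that is not named here; a higher number here means that the compound lasts longer, a lower number that the compound disappears faster. Compound 2 at 1.25 h lies within the scatter of compound 1 at 1.6 h, and compound 3 at 0.217 h has the lowest number of the three.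

The next compound is compound 4 `Cc1cc(-n2nccn2)cc(C(=O)NNS(=O)(=O)c2ccccc2)c1F`, which differs from compound 2 as follows: 2H-1,2,3-triazol-2-yl in place of 1H-pyrazol-1-yl on an aromatic carbon. It carries 2H-1,2,3-triazol-2-yl in place of 1H-pyrazol-1-yl on an aromatic carbon, para to a fluoro group.

Among the measured compounds shown here, no measured pair makes this exchange. For the measured compounds named here, the only measured step that bears on it, and only loosely, is a 7.4-fold lower number from compound 1 to compound 3 (0.87 log units; beyond the scatter). There 1H-pyrazol-1-yl also leaves, but allyloxy enters, on a different core. In the present case one five-membered aromatic ring replaces another, so no step beyond the scatter is expected in this assay, in either direction.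

The expected result is a 1.1-fold higher number from compound 2 to compound 4 (0.05 log units; within the scatter), an estimate that stays within the scatter.

Compound 4 is estimated at 1.4 h, with an expected range of 0.7 h to 2.8 h.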

Compound 4, half-life: 1.02 h
Beside the measured number, compound 4's estimate is 1.4-fold (0.14 log units) above it, and the stated range covers the measured number.
By their numbers in this assay, from the lowest: compound 3; then compounds 4, 2 and 1 (each within the scatter of the next).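

In this assay, the exchange on the aromatic carbon para to a fluoro group gives a 1.2-fold lower number from compound 2 to compound 4 (0.09 log units; within the scatter), so on this core 2H-1,2,3-triazol-2-yl and 1H-pyrazol-1-yl cannot be told apart by this read-out. Among the compounds shown here, this single pair shows that one more ring nitrogen in the five-membered aromatic ring leaves the number within the scatter, whereas the only earlier step at a comparable place, a 7.4-fold lower number from compound 1 to compound 3 (0.87 log units; beyond the scatter) on a different core, involved allyloxy and lay beyond it. Nothing measured here offers a reason for this result.

As far as these compounds go, how an amine, a carboxylic acid or a longer alkyl chain would read at this position remains open. Also open, from the compounds shown here alone, is whether the same ring exchange would stay within the scatter on the core of compound 1.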